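Moving the chlorine on the styryl ring: compound 4

The compounds below may be only part of what the source reports. "The series", "measured", "known", "first", "only" and "open" are said of these compounds alone.

Measured so far:
compound 1 `CN1CC[C@H](c2c(O)cc(O)c3c(=O)cc(/C=C/c4ccc(Cl)cc4)oc23)[C@H](O)C1` — 31000 nM
compound 2 `CN1CC[C@H](c2c(O)cc(O)c3c(=O)cc(/C=C/c4cccc(Cl)c4)oc23)[C@H](O)C1` — 10000 nM
compound 3 `CN1CC[C@H](c2c(O)cc(O)c3c(=O)cc(/C=C/c4c(F)c(F)c(F)c(F)c4F)oc23)[C@H](O)C1` — 2000 nM

All three share one core and differ only in the aryl group on a double-bonded chain carbon. In a functional assay on PC-3 cells (Homo sapiens) for inhibition, read by MTT assay, with a stated time of 48 h (a higher number here means a weaker inhibitor of growth, a lower number a stronger inhibitor of growth), compound 3 gives the lowest of the three numbers, so it is the strongest growth inhibitor here: compound 2 is its nearest neighbour, and compound 1 the furthest.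

Compound 4 `CN1CC[C@H](c2c(O)cc(O)c3c(=O)cc(/C=C/c4ccccc4Cl)oc23)[C@H](O)C1` has not yet been measured. It differs from compound 3 in one place: 2-chlorophenyl in place of 2,3,4,5,6-pentafluorophenyl on a double-bonded chain carbon bound to a double-bonded chain carbon

The measured steps that bear on this are those that also exchanged the pentafluorophenyl for a single-chlorine phenyl, in the opposite direction: a 5.0-fold lower number from compound 2 to compound 3 (0.70 log units; beyond the scatter) and a 16-fold lower number from compound 1 to compound 3 (1.19 log units; beyond the scatter). Both show that replacing a chlorophenyl with the pentafluorophenyl gave a lower number, modest in one case and large in the other. Reversing that change, whichever way the chlorine is placed, therefore points to a higher number for compound 4 in this assay, so a modest-to-large rise is expected, a 4.0-fold higher number from compound 3 to compound 4 (0.60 log units; beyond the scatter).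

The estimate for compound 4 in this assay is 8000 nM, expected to lie between 2500 nM and 25000 nM.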

Compound 4, concentration for 50% growth inhibition: 17000 nM
Beside the measured number, compound 4's estimate is 2.1-fold (0.33 log units) below it; low and high end bracket the measured number.
By their numbers in this assay, from the lowest: compound 3; then compounds 2, 4 and 1 (each within the scatter of the next, the first and the last beyond it).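

In this assay, the 2-chlorophenyl group adds a third placement of the chlorine, and it stands apart from neither of the other two placements (a 1.7-fold higher number from compound 2 to compound 4 (0.23 log units; within the scatter)) (a 1.8-fold lower number from compound 1 to compound 4 (0.26 log units; within the scatter)). Chlorine placement therefore gives no clean three-way order: the 3-chlorophenyl and 4-chlorophenyl groups differ beyond the scatter (a 3.1-fold lower number from compound 1 to compound 2 (0.49 log units; beyond the scatter)), yet the 2-chlorophenyl group cannot be told apart from either. The larger exchange holds for this third chlorophenyl group too (an 8.5-fold higher number from compound 3 to compound 4 (0.93 log units; beyond the scatter)), so compound 3, with its 2,3,4,5,6-pentafluorophenyl group, now lies beyond the scatter of all three chlorine compounds and is the strongest growth inhibitor of these four.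

No supporting measurement offers a reason for the gap between the pentafluorophenyl group and the chlorophenyl groups. From the compounds shown here alone, it remains open whether that gap follows the number of fluorine atoms or the absence of chlorine, and how a plain phenyl, a 4-fluorophenyl or a phenyl carrying an amine or a carboxylic acid would compare on the same double-bonded chain carbon.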